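This account rests on a few compounds, and the source may have more. Where it says the series, first, only, none or still open, it means among the compounds named here.

Compound 1 `CCCC(=O)c1ccc(OCCCCOc2cccc(C(=O)O)c2C)c(C)c1O` gives 53% in an assay on HEK293 cells for positive allosteric modulation of metabotropic glutamate receptor 3 (Rattus norvegicus), read by thallium flux, with a stated time of 2.5 min; a lower number here means a smaller maximal response, a higher number a larger maximal response.
Compound 2 `Cc1c(OCCCCOc2ccc(C(=O)C(C)C)c(O)c2C)cccc1C(=O)O` gives 27.1% in this assay.
Compound 3 `Cc1c(OCCCCOc2ccc(C(=O)CC(C)(C)C)c(O)c2C)cccc1C(=O)O` gives 109% in this assay.

Compound 3 stands highest of the three: compound 1 comes nearest, with a number 56 percentage points higher from compound 1 to compound 3 (beyond the scatter), and compound 2 lies furthest, with a number 81.9 percentage points higher from compound 2 to compound 3 (beyond the scatter). Both steps go the same way: the arrival of tert-butyl at the saturated chain carbon bound to the carbonyl carbon came with a large rise, while between the two lower compounds the step of a number 25.9 percentage points lower from compound 1 to compound 2 (beyond the scatter) was only modest.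

Compound 4 `CC(=O)c1ccc(OCCCCOc2cccc(C(=O)O)c2C)c(C)c1O` has not yet been measured in this assay. Compared with compound 3 it differs in one place: hydrogen in place of tert-butyl on a saturated chain carbon bound to a carbonyl carbon. This takes away the group that is present in compound 3 and absent in both lower compounds, and leaves a shorter chain than any of the three measured ketones carries. The steps of a number 56 percentage points higher from compound 1 to compound 3 (beyond the scatter) and a number 81.9 percentage points higher from compound 2 to compound 3 (beyond the scatter) therefore bear most directly, and they point to a sizeable fall in this assay for compound 4, likely carrying it back to or below the level of compound 1. Where exactly it lands is uncertain, since no measured compound carries so small a group at this position. The expected step is a number 64 percentage points lower from compound 3 to compound 4 (beyond the scatter). Compound 4 is estimated at 45%, with a range from 15% to 80%.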

Compound 4, largest response reached (reported as percent of maximum), in percent of the reference or control that the assay uses: 17.1%
For compound 4 the middle estimate is 27.9 percentage points above the measured one, within the range that was stated.
By their numbers in this assay, from the lowest: compounds 4 and 2 (each within the scatter of the next); then compound 1; then compound 3.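

Cutting the neopentyl group back to methyl on the carbonyl carbon removes most of the response in this assay, with a number 91.9 percentage points lower from compound 3 to compound 4 (beyond the scatter), so the high value of compound 3 is not shared by the ketone with the shortest chain in this set. The low end of the series also becomes clearer: a number 10 percentage points lower from compound 2 to compound 4 (within the scatter), which means the isopropyl and methyl ketones cannot be told apart, whereas a number 35.9 percentage points lower from compound 1 to compound 4 (beyond the scatter) shows that the straight propyl ketone stands clear of the methyl ketone, so compound 2 goes against any simple rise in response with each added carbon. The data offer no measurement that explains why these groups give such different responses.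

As far as these compounds go, it remains open whether the response keeps climbing past neopentyl or falls away with a longer chain such as hexyl, or with a ring such as cyclohexyl, on the carbonyl carbon. Also unsettled is whether the tert-butyl end of the chain could be replaced by an amine or a carboxylic acid and keep a response like that of compound 3.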